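A few compounds are considered here, and "the series" means these few. Any claim that something is new, unique, unknown or untested is made for them only; others in the source may bear on it.

Among the measured compounds shown here, in a functional assay on SW480 cells (Homo sapiens) for antiproliferative activity, read by MTT assay, with a stated time of 48 h (a higher number here means a weaker inhibitor, a lower number a stronger inhibitor), compound 1 `CCCCC(CCO)n1cnc2c(Cl)nc(F)nc21` gives 13200 nM and compound 2 `CCCCCCCCC(CCO)n1cnc2c(Cl)nc(F)nc21` gives 15000 nM, so compound 2 stands within the scatter of the only other measured compound. Compound 3 `CCCCCCCCCC(CCO)n1cnc2c(Cl)nc(F)nc21` differs from compound 2 by methyl in place of hydrogen on a saturated chain carbon, nine bonds along the chain from an aromatic nitrogen: methyl in place of hydrogen on a saturated chain carbon. For the measured compounds named here, the one measured step that bears on this, butyl in place of hydrogen on a saturated chain carbon, is a 1.1-fold higher number from compound 1 to compound 2 (0.06 log units; within the scatter), which lies within the scatter. A change beyond the scatter is therefore not expected in this assay. The estimated step is a 1.0-fold higher number from compound 2 to compound 3 (0.01 log units; within the scatter). For compound 3, the expected value is 15500 nM, with an estimated range of 8500 nM to 27000 nM.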

Compound 3, half-maximal inhibitory concentration: 12500 nM
Beside the measured number, compound 3's estimate is 1.2-fold (0.09 log units) above it, within the range that was stated.
By their numbers in this assay, from the lowest: compounds 3, 1 and 2 (each within the scatter of the next).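

In this assay methyl on a saturated chain carbon, nine bonds along the chain from an aromatic nitrogen, gives a 1.2-fold lower number from compound 2 to compound 3 (0.08 log units; within the scatter) and so adds a second step within the scatter. Pentyl in place of hydrogen, five bonds along the chain from an aromatic nitrogen, gives a 1.1-fold lower number from compound 1 to compound 3 (0.02 log units; within the scatter) and is also within the scatter, so these three compounds show no dependence on chain length. Nothing available here accounts for this result. Still open, from the compounds shown here alone, is whether an amine or a carboxylic acid in place of this plain carbon chain, or a much longer chain, would give a step beyond the scatter.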